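Ring replacement on the amide nitrogen of compound 2

This account rests on a few compounds, and the source may have more. Where it says the series, first, only, none or still open, it means among the compounds named here.

Compound 1, `CC(C)C[C@H](NC(=O)OCc1ccccc1)C(=O)NC1CCCC1=O`: in an assay on isolated protein for inhibition of cathepsin S (Homo sapiens) (a lower number here means a stronger inhibitor, a higher number a weaker inhibitor), compound 1 gives > 10000 nM, a limit of the assay and not a number.
Compound 2, `CC(C)C[C@H](NC(=O)OCc1ccccc1)C(=O)NC1CCCCC1=O`: in this assay compound 2 gives > 10000 nM, likewise a limit.

Compound 2 therefore stands only at a limit. The step that the two limits leave unreadable from compound 1 to compound 2 stays unreadable because both values sit at the limit of > 10000 nM in this assay, at which 2 of the 2 values shown sit. Compound 3, `CC(C)C[C@H](NC(=O)OCc1ccccc1)C(=O)NC1COCC1O`, differs by 4-hydroxyoxolan-3-yl in place of 2-oxocyclohexyl on an amide-type nitrogen. Among the compounds with values here, no measured step bears a readable size on this change, so no direction beyond the scatter can be drawn for this assay. Compound 3 is expected to stay at or near the limit, estimated at 20000 nM within 5000 nM to 100000 nM. The step this estimate implies, a step that the limit leaves unreadable from compound 2 to compound 3, is expected to lie within the scatter.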

Compound 3, inhibition constant: > 1000 nM
Compound 3 gave a limit, no number (the forecaster's own chance of this, stated with the estimate: 80%); the middle value does not contradict the limit.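

Compound 3 gives > 1000 nM in this assay, a limit and not a number. Its steps from compound 1 and compound 2 therefore cannot be read. The compounds shown leave open whether any of these three ring groups on the amide-type nitrogen differs from the others in this assay.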